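Aryl ketone in place of pyrrolidinyl ketone in the series

The compounds below may be only part of what the source reports. "The series", "measured", "known", "first", "only" and "open" are said of these compounds alone.

Measured so far:
compound 1, `O=C(/C(=C\c1ccc(O)c([N+](=O)[O-])c1)SCc1ccc(Br)cc1)C1CCNC1`: > 100000 nM (a limit)
compound 2, `O=C(O)c1ccc(C(=O)/C(=C\c2ccc(Cl)c([N+](=O)[O-])c2)SCc2ccccc2F)cc1`: 1000 nM
compound 3, `COc1ccccc1/C=C(\C(=O)c1ccc(Br)cc1)S(=O)(=O)c1ccc(C)cc1`: 1000 nM

In a functional assay on DU-145 cells (Homo sapiens) for inhibition, read by trypan blue exclusion, with a stated time of 96 h (a higher number here means a weaker inhibitor of growth, a lower number a stronger inhibitor of growth), compound 1 gives only a limit, > 100000 nM, so no number is known for it. This is the limit of > 100000 nM in this assay, at which 1 of the 3 values shown sits. Compound 2 gives 1000 nM in this assay, and compound 3 gives 1000 nM; these two values lie within the scatter of one another.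

Compound 4, `O=C(O)c1ccc(C(=O)/C(=C\c2ccc(O)c([N+](=O)[O-])c2)SCc2ccc(Br)cc2)cc1`, is not yet measured. It differs from compound 1 in one place: 4-carboxyphenyl in place of pyrrolidin-3-yl on a carbonyl carbon. Compound 4 carries the same 4-carboxyphenyl ketone as compound 2, with a nitrophenyl and a benzylthio group like it, so the comparison with compound 2 is the closest one available.

For the measured compounds named here, no step between measured compounds is on hand for this change. The expected step of an at least 50-fold lower number from compound 1 to compound 4 (1.69 log units; beyond the scatter) is large and toward stronger growth inhibition, well beyond the scatter, because compound 2 gives 1000 nM with a ketone of this kind. Compound 4 is therefore estimated at 2000 nM, in the range 500 nM to 20000 nM.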

Compound 4, concentration for 50% growth inhibition: 50000 nM
Compound 4: middle estimate off by 25-fold (1.40 log units), on the low side; measured number above the stated range.
By their numbers in this assay, from the lowest: compounds 2 and 3 (each within the scatter of the next); then compound 4. At a limit, above all of these: compound 1.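

In this assay compound 1 gives > 100000 nM as a limit of the assay and not as a number. For the compounds shown here, with 4-carboxyphenyl in place of pyrrolidin-3-yl on a carbonyl carbon, the series shows an at least 2.0-fold lower number from compound 1 to compound 4 (0.30 log units; that floor lies within the scatter) as the first step at this position, and compound 4 gives a value that can be read. The true size of this step remains unknown because one end of it is only a limit: the limit of > 100000 nM in this assay, at which 1 of the 4 values shown sits.

As far as these compounds go, whether the aromatic ring or the carboxylic acid on it carries the step stays open, and a plain phenyl or a methyl ester on the same carbonyl carbon would separate the two. Compound 2 differs from compound 4 in more than one place, so the gap between their values cannot be assigned to any single group.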